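Moving the chlorine around the anilino ring

The compounds below may be only part of what the source reports. "The series", "measured", "known", "first", "only" and "open" are said of these compounds alone.

Compound 1 `Cc1n[nH]c2ccc(-c3nc4cnc(N5CCN(C)CC5)cn4c3Nc3ccc(F)cc3)cc12` gives 0% in a functional assay on MV4-11 cells (Homo sapiens) for inhibition, with a stated time of 120 h, tested at 10 uM; a lower number here means less inhibition, a higher number more inhibition at the concentration tested (going by the name of the read-out).
Compound 2 `Cc1n[nH]c2ccc(-c3nc4cnc(N5CCN(C)CC5)cn4c3Nc3ccccc3Cl)cc12` gives 58.1% in this assay.

Going by the values given here, compound 2 stands highest of the two numbers in this assay, and its only neighbour, compound 1, lies far below it: the single measured step is a number 58.1 percentage points higher from compound 1 to compound 2 (beyond the scatter), and that step changes both the halogen and where it sits on the ring. Compound 3 `Cc1n[nH]c2ccc(-c3nc4cnc(N5CCN(C)CC5)cn4c3Nc3ccc(Cl)cc3)cc12` differs from compound 2 by 4-chlorophenyl in place of 2-chlorophenyl on a nitrogen on an aromatic ring. So compound 3 keeps the chlorine of compound 2 but puts it at the position the fluorine occupies in compound 1. Among the compounds with values here, the only step that bears on this is a number 58.1 percentage points higher from compound 1 to compound 2 (beyond the scatter), and because compound 1 with its halogen at that position gives 0%, a large part of the gain seen in compound 2 is expected to be lost. Compound 3 is therefore estimated to fall by a number 43.1 percentage points lower from compound 2 to compound 3 (beyond the scatter) in this assay, to about 15%, with a range from 0% to 45%.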

Compound 3, a percentage reported as inhibition, at one concentration (the size of the read-out at that concentration, not a potency): 83.7%
Beside the measured number, compound 3's estimate is 68.7 percentage points below it; measured number above the stated range.
By their numbers in this assay, from the lowest: compound 1; then compound 2; then compound 3.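

Moving the chlorine from the 2-chlorophenyl of compound 2 to the 4-chlorophenyl of compound 3 gives a number 25.6 percentage points higher from compound 2 to compound 3 (beyond the scatter) in this assay, so the chlorine does not need to stay at the earlier place to keep inhibition. Changing only the halogen, with its place on the ring unchanged, gives a number 83.7 percentage points higher from compound 1 to compound 3 (beyond the scatter), which shows that the empty result of compound 1 belongs to the fluoro group and not to the place it occupies. Nothing measured here explains why chloro and fluoro differ so sharply on this ring.

Still open, as far as these compounds go, is whether a plain phenyl with no halogen, a 4-bromophenyl or a 4-methoxyphenyl would match compound 3, and whether a 2-fluorophenyl would inhibit at all. From the compounds shown here alone, each number is also a reading at one concentration, so how potent these compounds are remains unknown.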